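Nitrophenyl Thiourea in Place of a Dimethylphenyl Urea

The source may hold more compounds than are shown below. What is called first, only, known or untested is meant among the compounds shown, and "the series" means these compounds.

In a functional assay on HL-60 cells (Homo sapiens) for inhibition, read by CCK-8 assay, with a stated time of 48 h (a higher number here means a weaker inhibitor, a lower number a stronger inhibitor), compound 3 `Cc1cc(C)cc(NC(=O)NCCNS(=O)(=O)c2ccc(-c3ccccc3OCc3cccc(O)c3)s2)c1` gives > 20000 nM, which is a limit of the assay rather than a measured number. Its closest measured neighbour, compound 2 `O=C(NCCNS(=O)(=O)c1ccc(-c2ccccc2OCc2cccc(O)c2)s1)Nc1cc(Cl)cc(Cl)c1`, gives 2800 nM in this assay. The one step measured among these compounds, an at least 7.1-fold higher number from compound 2 to compound 3 (0.85 log units; beyond the scatter), shows that the dimethyl pattern falls to the limit of the limit of > 20000 nM in this assay, at which 1 of the 3 values shown sits, while the dichloro pattern yields a number.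

Compound 4 `O=[N+]([O-])c1cccc(NC(=S)NCCNS(=O)(=O)c2ccc(-c3ccccc3OCc3cccc(O)c3)s2)c1` is obtained from compound 3 by the change (a group of 12 heavy atoms (7 carbon, 2 nitrogen, 2 oxygen, 1 sulfur; one six-membered aromatic ring of carbon only) in place of a group of 11 heavy atoms (9 carbon, 1 nitrogen, 1 oxygen; one six-membered aromatic ring of carbon only), on an amine nitrogen). Going by the values given here, no measured step covers this exact change. Among the compounds with values here, the only compound that already carries the entering group is compound 1 `O=[N+]([O-])c1cccc(NC(=S)NCCNS(=O)(=O)c2ccc(-c3ccccc3OCc3ccccc3)s2)c1`, which differs from compound 4 elsewhere in the structure. In this assay compound 1 gives > 50000 nM, again a limit of the assay, namely (the limit of > 50000 nM in this assay, at which 1 of the 3 values shown sits). Compound 3 and compound 1 therefore both sit at limits, and compound 4 shares its nitrogen substituent with one and the rest of its structure with the other.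

The step that the limit leaves unreadable from compound 3 to compound 4 is expected to stay within the scatter, with compound 4 most likely reported again as a limit. The estimate for compound 4 is 35000 nM, with a range from 6000 nM to 100000 nM.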

Compound 4, half-maximal inhibitory concentration: 11400 nM
The estimate for compound 4 lay 3.1-fold (0.49 log units) above the measured number; the measured number falls inside the stated range.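

In this assay, going by these compounds alone, hydroxy in place of hydrogen on an aromatic carbon gives an at least 4.3-fold lower number from compound 1 to compound 4 (0.64 log units; beyond the scatter), a step measured against a limit, and it is the first sign that this hydroxy group matters while the nitrophenyl thiourea stays fixed. Against the 3,5-dichlorophenyl urea of compound 2, the nitrophenyl thiourea gives a 4.1-fold higher number from compound 2 to compound 4 (0.61 log units; beyond the scatter), so on this amine nitrogen the dichlorophenyl urea remains the better of this pair. In place of the (3,5-dimethylphenyl)carbamoyl group, the same nitrophenyl thiourea gives an at least 1.7-fold lower number from compound 3 to compound 4 (0.24 log units; that floor lies within the scatter), which does not separate the two groups, and compound 3 is only a limit here: the limit of > 20000 nM in this assay, at which 1 of the 4 values shown sits.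

The entering group differs from both ureas in the ring substituent and in having sulfur where they have oxygen, so the compounds shown do not tell the thiourea's share from the nitro group's share. A 3,5-dichlorophenyl thiourea on the same core, or an amine or a carboxylic acid in place of the nitro group, would be needed to pull these two parts apart.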